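Compound 3: hydrogen in place of chloro

The compounds below may be only part of what the source reports. "The series", "measured", "known", "first", "only" and "open" are said of these compounds alone.

Working notes on the series. In a functional assay on the whole organism with Mus musculus as the target (on this read-out lower numbers stand for an effect already at smaller amounts and higher numbers for an effect only at larger amounts of compound), compound 1 (`COc1cc2c(cc1OC)C(c1ccc(Br)cc1)=NN=C(S)C2`) gives 52.1 umol/kg and compound 2 (`COc1cc2c(cc1OC)C(c1ccc(Cl)cc1)=NN=C(S)C2`) gives 82.4 umol/kg on the same core. Compound 2 therefore stands level with compound 1 within the scatter, and these two numbers are all that is available so far.

The change to compound 3 (`COc1cc2c(cc1OC)C(c1ccccc1)=NN=C(S)C2`) is hydrogen in place of chloro on an aromatic carbon on an aromatic carbon of a six-membered aromatic ring of carbon only, para to a large group, which reads as 4-chlorophenyl to phenyl.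

Among the compounds with values here, only one measured step bears on this: a 1.6-fold higher number from compound 1 to compound 2 (0.20 log units; within the scatter) for chloro in place of bromo on an aromatic carbon. Within the data shown here, that step exchanges one halogen for another, and no compound without a halogen there has been measured, so the evidence is indirect. On this basis, no step beyond the scatter is expected in this assay and the range is kept wide. The estimated step is a 1.1-fold higher number from compound 2 to compound 3 (0.04 log units; within the scatter) and remains an expectation. For compound 3 the estimated dose is 90 umol/kg (expected range 38 umol/kg to 210 umol/kg).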

Compound 3, dose for half-maximal effect: 19.7 umol/kg
Compound 3: the middle estimate sits 4.6-fold (0.66 log units) above what was measured; measured number below the stated range.
By their numbers in this assay, from the lowest: compound 3; then compounds 1 and 2 (each within the scatter of the next).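

In this assay, what matters at this aromatic carbon is whether a halogen is present at all, not which of the two halogens it is: the hydrogen compound shows a 4.2-fold lower number from compound 2 to compound 3 (0.62 log units; beyond the scatter) and a 2.6-fold lower number from compound 1 to compound 3 (0.42 log units; beyond the scatter), while the exchange of bromo for chloro gave only a 1.6-fold higher number from compound 1 to compound 2 (0.20 log units; within the scatter) in the earlier pair. The 4-chlorophenyl to phenyl change therefore shows that this position is not indifferent to its substituent, and among the three compounds the plain phenyl of compound 3 gives the lowest number, with both of its steps beyond the scatter. Nothing at hand on the compounds explains why the halogens raise the dose needed for the effect, so the finding stands as an observation only. With only hydrogen, chloro and bromo shown at this position, it remains open whether hydrogen is the best choice there or whether a methoxy group, an amine or a carboxylic acid would lower the number further. As far as these compounds go, it is equally open whether the same order would hold if the two methoxy groups on the shared core were replaced by another group, such as a longer alkoxy chain.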